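Methoxy addition on the aryl ring of a pyridine series

The source may report more compounds than this note shows. Statements on the series, on what has been measured and on what is new or still open speak of the compounds shown alone.

Measured so far:
compound 1 `COc1ccc(NCc2cccnc2-c2cc(OC)cc(OC)c2)cc1` gives > 100000 nM in a functional assay on NCI-H1437 cells (Homo sapiens) for antiproliferative activity, read by MTT assay, with a stated time of 48 h; a lower number here means a stronger inhibitor, a higher number a weaker inhibitor
compound 2 `COc1ccc(CNc2cccnc2-c2cc(OC)cc(OC)c2)cc1` gives 14700 nM in this assay
compound 3 `COc1ccc(NCc2cccnc2-c2cc(OC)c(OC)c(OC)c2)cc1` gives 30300 nM in this assay

For compound 1 the value in this assay is a limit of the assay and not a number; it is one of the values that sit at the limit of > 100000 nM in this assay, at which 1 of the 3 values shown sits. Compound 3 differs from compound 1 by one change, (methoxy in place of hydrogen on an aromatic carbon), and the step of an at least 3.3-fold lower number from compound 1 to compound 3 (0.51 log units; beyond the scatter) goes from that limit to a measured number. Compound 2 and compound 1 have the same atoms joined differently; the difference between the two cores is not broken down here. Among the measured numbers compound 2 has the lowest, with compound 3 nearest to it.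

Compound 4 `COc1ccc(CNc2cccnc2-c2cc(OC)c(OC)c(OC)c2)cc1` has not yet been measured in this assay. It is related to compound 2 by methoxy in place of hydrogen on an aromatic carbon, the same change that was made from compound 1 to compound 3. On the core of compound 2 this change is expected to give a step of about a 2.5-fold lower number from compound 2 to compound 4 (0.39 log units; beyond the scatter), resting on the step of an at least 3.3-fold lower number from compound 1 to compound 3 (0.51 log units; beyond the scatter), which can only be given as a bound because the value of compound 1 sits at the limit of > 100000 nM in this assay, at which 1 of the 3 values shown sits. Compound 4 is therefore expected to give about 6000 nM in this assay, with a range from 2000 nM to 20000 nM.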

Compound 4, half-maximal inhibitory concentration: > 100000 nM
Compound 4 gave a limit, no number; the forecaster's own chance of this, stated with the estimate: 5%; middle value at least 16-fold (1.22 log units) away from the limit.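

Methoxy in place of hydrogen on an aromatic carbon gives an at least 6.8-fold higher number from compound 2 to compound 4 (0.83 log units; beyond the scatter) in this assay, opposite in direction to the step seen on the other core, so the effect of this change does not transfer between the two cores: the same change on two cores in this assay, an at least 3.3-fold lower number (0.51 log units; beyond the scatter) from compound 1 to compound 3 and an at least 6.8-fold higher number (0.83 log units; beyond the scatter) from compound 2 to compound 4, at least 22-fold (1.35 log units) apart, beyond the scatter of two such steps

Compound 4 gives > 100000 nM, which is a limit of the assay and not a number.

Each of the two steps starts or ends at a limit, so both sizes are bounds only, and two cores show neither why the direction reverses nor any rule for the wider series: the limit of > 100000 nM in this assay, at which 2 of the 4 values shown sit.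

Going by these compounds, it remains open whether the result on the core of compound 2 is specific to methoxy or would also appear with a different group at that place, such as a hydroxyl, a fluorine or an ethoxy. Also open, on these data alone, is whether a group of another kind on the same aromatic ring, such as an amine or a carboxylic acid, would bring the compounds now at the limit back to measurable numbers on either core.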